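Dipropylamino in Place of Anilino on the Shared Core

This account rests on a few compounds, and the source may have more. Where it says the series, first, only, none or still open, it means among the compounds named here.

compound 1, `COc1cccc(NC2=CC(=O)c3nc4n(c3C2=O)[C@H]2OC[C@@H](O)[C@H]2OC4)c1`: 1780 nM
compound 2, `CCCc1ccc(NC2=CC(=O)c3nc4n(c3C2=O)[C@H]2OC[C@@H](O)[C@H]2OC4)cc1`: 1560 nM
compound 3, `CCCN(CCC)C1=CC(=O)c2c(nc3n2[C@H]2OC[C@@H](O)[C@H]2OC3)C1=O`: > 16000 nM

In a functional assay on MGC-803 cells (Homo sapiens) for inhibition, read by sulforhodamine B assay (a higher number here means a weaker inhibitor, a lower number a stronger inhibitor), compound 1 gives 1780 nM and compound 2 gives 1560 nM, the two numbers differing only within the scatter, as the step of a 1.1-fold lower number from compound 1 to compound 2 (0.06 log units; within the scatter) shows. For compound 3 the result is only a limit, > 16000 nM, at the limit of > 16000 nM in this assay, at which 1 of the 3 values shown sits. Compound 4, `CCCN(CCC)C1=CC(=O)c2nc3n(c2C1=O)[C@H]1OC[C@@H](O)[C@H]1OC3`, is not yet measured and differs from compound 1 by dipropylamino in place of (3-methoxyphenyl)amino on a double-bonded ring carbon. Among the compounds with values here, no measured step covers this change: the one step known, a 1.1-fold lower number from compound 1 to compound 2 (0.06 log units; within the scatter), exchanges one arylamino for another and stays within the scatter. Compound 3, which also carries dipropylamino, gives only a limit, > 16000 nM. Compound 4 is therefore expected to weaken markedly, a 6.7-fold higher number from compound 1 to compound 4 (0.83 log units; beyond the scatter), with an estimate of 12000 nM between 4000 nM and 40000 nM.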

Compound 4, half-maximal inhibitory concentration: > 16000 nM
Compound 4: only a limit was reported (the forecaster's own chance of this, stated with the estimate: 45%); at least 1.3-fold (0.12 log units) between middle value and limit.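

In this assay, dipropylamino in place of (3-methoxyphenyl)amino on the double-bonded ring carbon gives an at least 8.9-fold higher number from compound 1 to compound 4 (0.95 log units; beyond the scatter), whereas exchanging one arylamino group for another gave only a 1.1-fold lower number from compound 1 to compound 2 (0.06 log units; within the scatter). This position therefore tolerates that exchange but not this change to dipropylamino. Compound 4 gives only a limit, so the step has a floor but no measured size: the limit of > 16000 nM in this assay, at which 2 of the 4 values shown sit.

The aromatic ring and the amine hydrogen leave together in this change, so the compounds shown do not separate them. Propylamino would keep the hydrogen without the ring, and N-methylanilino would keep the ring without the hydrogen.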